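The source may report more compounds than this note shows. Statements on the series, on what has been measured and on what is new or still open speak of the compounds shown alone.

Among the compounds with values here, the three compounds measured so far share one core and differ only in the group attached to the carbonyl carbon of the amide. Compound 1 `Cc1ccc(C(=O)Nc2cccc(-c3oc4cc(-c5ccc(F)cc5)ccc4c(=O)c3O)c2)cc1` gives 12900 nM in a functional assay on GTL 16 cells for antiproliferative activity against GTL 16 cell line (Homo sapiens), read by CCK-8 assay, with a stated time of 72 h; on this read-out higher numbers stand for weaker inhibition and lower numbers for stronger inhibition. Compound 2 `O=C(Nc1cccc(-c2oc3cc(-c4ccc(F)cc4)ccc3c(=O)c2O)c1)c1ccc(Cl)cc1` gives 9140 nM in this assay, and compound 3 `O=C(Nc1cccc(-c2oc3cc(-c4ccc(F)cc4)ccc3c(=O)c2O)c1)c1ccc(F)cc1F` gives 9640 nM in this assay. Compound 1 stands at the highest number of the three, but the steps of a 1.4-fold lower number from compound 1 to compound 2 (0.15 log units; within the scatter) and a 1.3-fold lower number from compound 1 to compound 3 (0.13 log units; within the scatter) both lie within the scatter, as does a 1.1-fold higher number from compound 2 to compound 3 (0.02 log units; within the scatter), so the three compounds cannot be ordered on these numbers.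

Compound 4 `COc1cccc(C(=O)Nc2cccc(-c3oc4cc(-c5ccc(F)cc5)ccc4c(=O)c3O)c2)c1` has not yet been measured. It differs from compound 1 in one place: 3-methoxyphenyl in place of 4-methylphenyl on a carbonyl carbon. The measured steps that bear on this change are the two in which the group on the carbonyl carbon was exchanged, a 1.4-fold lower number from compound 1 to compound 2 (0.15 log units; within the scatter) and a 1.3-fold lower number from compound 1 to compound 3 (0.13 log units; within the scatter); neither moved beyond the scatter. The change to compound 4 is of the same kind, an exchange of the group on the carbonyl carbon, so no step beyond the scatter is expected in this assay. Compound 4 is therefore estimated at 11500 nM, with a range from 5000 nM to 28000 nM, which means an expected step of a 1.1-fold lower number from compound 1 to compound 4 (0.05 log units; within the scatter).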

Compound 4, half-maximal inhibitory concentration: 12500 nM
Beside the measured number, compound 4's estimate is 1.1-fold (0.04 log units) below it, within the range that was stated.
By their numbers in this assay, from the lowest: compounds 2, 3, 4 and 1 (each within the scatter of the next).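

In this assay, the exchange of 4-methylphenyl for 3-methoxyphenyl on the carbonyl carbon adds an oxygen and a hydrogen-bond acceptor to the group, yet the result, a 1.0-fold lower number from compound 1 to compound 4 (0.01 log units; within the scatter), stays within the scatter. The new group also fails to separate from the two halogen-bearing groups, with a 1.3-fold higher number from compound 3 to compound 4 (0.11 log units; within the scatter) and a 1.4-fold higher number from compound 2 to compound 4 (0.14 log units; within the scatter) both within the scatter as well, so the four substituted phenyl groups now shown at this position cannot be ordered on these numbers, and a group carrying an oxygen and an acceptor reads the same as those without such an oxygen. No measurement shown here offers an explanation for this lack of separation.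

Going by these compounds, all four compounds carry a substituted phenyl ring on the carbonyl carbon, so it remains open whether an amine, a carboxylic acid or a longer chain at this position would give a step beyond the scatter. On these data alone, all four also share the same core with its 4-fluorophenyl group, and what a change there would do to the number in this assay remains equally open.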